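Shortening the chain on the ring amine nitrogen

The source may report more compounds than this note shows. Statements on the series, on what has been measured and on what is new or still open speak of the compounds shown alone.

Three compounds have been measured in a functional assay (strain AB) with Danio rerio as the target, read by microscopy, with a stated time of 1 h; a lower number here means that less compound is needed, a higher number that more compound is needed for the effect:

compound 1 `CC(C)(C)CN1CCc2c(sc(NC(=O)Nc3ccc(Cl)cc3)c2C(N)=O)C1` — 5560 nM
compound 2 `CCN1CCc2c(sc(NC(=O)NCC3CCCO3)c2C(N)=O)C1` — > 25000 nM, which is a limit of this assay rather than a number
compound 3 `CC(C)(C)OC(=O)CCCC[N+]1(C)CCc2c(sc(NC(=O)Nc3ccc(Cl)cc3)c2C(N)=O)C1` — 140 nM

Among the two numbers that were obtained, compound 1 carries the highest one. Its nearest neighbour in this assay is compound 3, whose number is lower by a gap well beyond the scatter. Compound 2 adds no number to the comparison: the limit of > 25000 nM in this assay, at which 1 of the 3 values shown sits.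

The step under consideration leads from compound 1 to compound 4 `CCCN1CCc2c(sc(NC(=O)Nc3ccc(Cl)cc3)c2C(N)=O)C1`, which has not yet been measured in this assay. The two structures differ in one place: ethyl in place of tert-butyl on a saturated chain carbon bound to an amine nitrogen in a ring. Among the measured compounds shown here, no measured pair in this set isolates that same change, so the expected size of the step has to be judged without a direct precedent. The group that leaves and the group that enters are both saturated chains with no donors, acceptors or charge, so a small step is expected, in either direction, possibly none beyond the scatter.

Compound 4 is therefore expected to give about 8000 nM in this assay, within a range from 2500 nM to 25000 nM. That estimate corresponds to a step of a 1.4-fold higher number from compound 1 to compound 4 (0.16 log units; within the scatter).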

Compound 4, half-maximal effective concentration: 3500 nM
Compound 4: the middle estimate sits 2.3-fold (0.36 log units) above what was measured; low and high end bracket the measured number.
By their numbers in this assay, from the lowest: compound 3; then compounds 4 and 1 (each within the scatter of the next). At a limit, above all of these: compound 2.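

In this assay the change from neopentyl to propyl, on a saturated chain carbon bound to an amine nitrogen in a ring, gives a 1.6-fold lower number from compound 1 to compound 4 (0.20 log units; within the scatter) and so leaves the number where it was within the usual variation of repeated measurements. Among the compounds shown here, this pair is the first in the set to differ in one place only, and it shows that, for these two saturated chains, replacing tert-butyl with ethyl at this position does not move the result in this assay by more than that variation. Nothing measured here bears on why this step is as small as it is.

The compounds shown leave open whether this insensitivity extends beyond these two chains, since a single pair of saturated groups cannot define how far this position tolerates change. A much longer chain, a cyclohexyl ring, or a chain ending in a carboxylic acid or a primary amine at this same place could each give a different result, and the compounds shown offer no reading for any of these.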